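This account rests on a few compounds, and the source may have more. Where it says the series, first, only, none or still open, it means among the compounds named here.

Working notes on the series. In a functional assay on SMMC-7721 cells (Homo sapiens) for inhibition, read by MTT assay, with a stated time of 48 h (a lower number here means a stronger inhibitor, a higher number a weaker inhibitor), compound 1 `Nc1n[nH]c2cccc(-c3cccc(NC(=O)Nc4ccc(Cl)cc4Cl)c3)c12` gives 1900 nM and compound 2 `Nc1n[nH]c2cccc(-c3cccc(NC(=O)Nc4cc(C(F)(F)F)cc(C(F)(F)F)c4)c3)c12` gives 3540 nM, so compound 2 stands within the scatter of compound 1. Compound 3 `Nc1n[nH]c2cccc(-c3cccc(NC(=O)Nc4cccc(C(F)(F)F)c4)c3)c12` comes from compound 2 by hydrogen in place of trifluoromethyl on an aromatic carbon. Going by the values given here, no measured pair isolates this change. Starting from compound 2 at 3540 nM, no step beyond the scatter is expected in this assay, and no firm direction can be given. The estimated step, a 1.2-fold lower number from compound 2 to compound 3 (0.07 log units; within the scatter), is correspondingly small. For compound 3 the expected value is 3000 nM, with an estimated range of 1200 nM to 7500 nM.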

Compound 3, half-maximal inhibitory concentration: 1410 nM
Compound 3: the middle estimate sits 2.1-fold (0.33 log units) above what was measured; the range from low to high includes it.
By their numbers in this assay, from the lowest: compounds 3, 1 and 2 (each within the scatter of the next, the first and the last beyond it).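

In this assay, going by these compounds alone, hydrogen in place of one trifluoromethyl gives a 2.5-fold lower number from compound 2 to compound 3 (0.40 log units; beyond the scatter), the first step that clears the scatter, so this place on the aromatic ring does respond to the change. By contrast, 3-(trifluoromethyl)phenyl in place of 2,4-dichlorophenyl on the amide-type nitrogen gives a 1.3-fold lower number from compound 1 to compound 3 (0.13 log units; within the scatter), so these two aryl groups are not told apart here. No measurement at hand accounts for either step.

The compounds shown leave open how a nitrile or an amine at this place would compare with hydrogen and trifluoromethyl, and what hydrogen in place of the remaining trifluoromethyl would give.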